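This account rests on a few compounds, and the source may have more. Where it says the series, first, only, none or still open, it means among the compounds named here.

Working notes on the series.

Compound 1 `O=C(c1ccc(C(F)(F)F)cc1)N1CCC(NS(=O)(=O)c2cc(S(=O)(=O)c3ccccc3)ccc2C(F)(F)F)CC1` and compound 2 `CC(C)(C)OC(=O)N1CC[C@@H](C(=O)N2CCC(NS(=O)(=O)c3cc(S(=O)(=O)c4ccccc4)ccc3C(F)(F)F)CC2)C1` share one core and differ only at the carbonyl carbon on the piperidine nitrogen. In an assay on isolated protein for displacement of a labelled ligand from secreted frizzled-related protein 1 (Homo sapiens), read by fluorescence polarization, with a stated time of 30 min (on this read-out higher numbers stand for weaker inhibition and lower numbers for stronger inhibition), compound 1 gives 400 nM. In this assay compound 2 gives 50 nM. Among the measured compounds shown here, the one measured step, an 8.0-fold lower number from compound 1 to compound 2 (0.90 log units; beyond the scatter), places compound 2 at the lowest number of the two, with compound 1 as its only neighbour.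

Compound 3 `O=C(CC1CCNCC1)N1CCC(NS(=O)(=O)c2cc(S(=O)(=O)c3ccccc3)ccc2C(F)(F)F)CC1` is not yet measured. Against compound 2 the change is (piperidin-4-yl)methyl in place of 1-(tert-butoxycarbonyl)pyrrolidin-3-yl on a carbonyl carbon. For the measured compounds named here, no measured step covers this exchange: the step from compound 1 to compound 2 swapped an aryl group for the carbamate-bearing pyrrolidine, and its size an 8.0-fold lower number from compound 1 to compound 2 (0.90 log units; beyond the scatter) only shows that the group on this carbonyl carbon matters to the read-out. Compound 3 removes that carbamate and brings in a ring bearing a hydrogen-bond donor, so the direction cannot be read from the step from compound 1 to compound 2 alone.

Compound 3 is therefore expected near 150 nM, within 30 nM to 700 nM, a step of a 3.0-fold higher number from compound 2 to compound 3 (0.48 log units; beyond the scatter) from compound 2 that is an estimate of modest weakening with wide uncertainty.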

Compound 3, half-maximal inhibitory concentration: 100 nM
Compound 3: middle estimate off by 1.5-fold (0.18 log units), on the high side, and the stated range covers the measured number.
By their numbers in this assay, from the lowest: compounds 2 and 3 (each within the scatter of the next); then compound 1.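

In this assay the exchange on this carbonyl carbon gives a 2.0-fold higher number from compound 2 to compound 3 (0.30 log units; within the scatter) and so leaves compound 2 and compound 3 indistinguishable, which shows that the 1-(tert-butoxycarbonyl)pyrrolidin-3-yl group with its carbamate is not required for a number of this size. Against the 4-(trifluoromethyl)phenyl group, the (piperidin-4-yl)methyl group gives a 4.0-fold lower number from compound 1 to compound 3 (0.60 log units; beyond the scatter) and thereby confirms the gain seen with compound 2 using a second, smaller group with a six-membered rather than a five-membered non-aromatic ring, so among these three compounds both groups with a non-aromatic ring give lower numbers than the 4-(trifluoromethyl)phenyl group. No supporting data bear on why these groups on this carbonyl carbon give these numbers.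

The compounds shown do not separate the contribution of the ring nitrogen of the (piperidin-4-yl)methyl group from that of its ring and methylene link, a question that a cyclohexylmethyl group, with carbon in place of that nitrogen, would address. From the compounds shown here alone, it also remains open how a carboxylic acid or a longer chain ending in an amine would read at this position.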